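Extending a benzyl ether by one phenyl ring

This account rests on a few compounds, and the source may have more. Where it says the series, first, only, none or still open, it means among the compounds named here.

Compound 3 `CN1Cc2ccc(O)cc2[C@@H](OCc2ccccc2)C1` was examined in an ADME assay on Vero cells (Chlorocebus sabaeus) for cytotoxicity, read by sulforhodamine B assay, with a stated time of 72 h; a higher number here means a weaker inhibitor, a lower number a stronger inhibitor. In this assay compound 3 gives only a limit, > 50000 nM, which is the edge of what the assay reports rather than a number (the limit of > 50000 nM in this assay, at which 1 of the 3 values shown sits). Compound 4 `CN1Cc2ccc(O)cc2[C@@H](OCc2ccc(-c3ccccc3)cc2)C1` differs from compound 3 in one place: phenyl in place of hydrogen on an aromatic carbon.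

The same kind of change has been measured once in this series. Compound 1 `CN1Cc2ccc(OCc3ccc(-c4ccccc4)cc3)cc2[C@@H](O)C1` gives 23000 nM in this assay, and compound 2 `CN1Cc2ccc(OCc3ccc(-c4ccc(-c5ccccc5)cc4)cc3)cc2[C@@H](O)C1` gives 280 nM; the step of an 82-fold lower number from compound 1 to compound 2 (1.91 log units; beyond the scatter) was large and beyond the scatter. The ether of compound 1 sits on the phenol oxygen of the shared core, whereas the ether of compound 3 sits on the alcohol oxygen, so the two series are not identical, but the added phenyl is the same group in the same place on its benzyl ring.

A lower number, beyond the scatter, is therefore expected for compound 4, with the step of an at least 6.2-fold lower number from compound 3 to compound 4 (0.79 log units; beyond the scatter). The value expected for compound 4 is 8000 nM, most likely between 1500 nM and 50000 nM.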

Compound 4, half-maximal inhibitory concentration: > 50000 nM
Compound 4: no number, only a limit; the forecaster's own chance of this, stated with the estimate: 25%; middle value at least 6.2-fold (0.79 log units) away from the limit.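

Compound 3 and compound 4 each give only a limit in this assay, not a number, so no step can be read between them: the limit of > 50000 nM in this assay, at which 2 of the 4 values shown sit.

As far as these compounds go, whether the added phenyl lowers the number for this pair, as it did between compound 1 and compound 2, remains open.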